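Swapping the ether for bromine on the fused ring

The source may hold more compounds than are shown below. What is called first, only, known or untested is meant among the compounds shown, and "the series" means these compounds.

Three compounds share a core and were tested in a functional assay on A549 cells (Homo sapiens) for cytotoxicity, with a stated time of 48 h; on this read-out lower numbers stand for stronger inhibition and higher numbers for weaker inhibition. Compound 1 `C[S+]([O-])/C=C/c1cc(=O)c2ccccc2o1` gives 1900 nM in this assay. Compound 2 `CC(C)COc1ccc2oc(/C=C/[S+](C)[O-])cc(=O)c2c1` gives 1100 nM, and compound 3 `CC(C)Oc1ccc2oc(/C=C/[S+](C)[O-])cc(=O)c2c1` gives 1500 nM, the second highest of the three numbers. Compound 4 `C[S+]([O-])/C=C/c1cc(=O)c2cc(Br)ccc2o1` differs from compound 3 by bromo in place of isopropoxy on an aromatic carbon. Within the data shown here, no measured step adds bromo; the steps that touch this position, a 1.3-fold lower number from compound 1 to compound 3 (0.10 log units; within the scatter), a 1.7-fold lower number from compound 1 to compound 2 (0.24 log units; within the scatter) and a 1.4-fold higher number from compound 2 to compound 3 (0.13 log units; within the scatter), all stayed within the scatter, so the group there seems to matter little. A step of a 1.1-fold higher number from compound 3 to compound 4 (0.03 log units; within the scatter) is therefore expected, within the scatter. Compound 4 is estimated at 1600 nM, with a range from 700 nM to 3600 nM.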

Compound 4, half-maximal inhibitory concentration: 1100 nM
Beside the measured number, compound 4's estimate is 1.5-fold (0.16 log units) above it; the range from low to high includes it.
By their numbers in this assay, from the lowest: compounds 2, 4, 3 and 1 (each within the scatter of the next).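

Bromo is a single heavy atom with no oxygen linking it to the ring, unlike isopropoxy and isobutoxy, yet in this assay the steps of a 1.4-fold lower number from compound 3 to compound 4 (0.13 log units; within the scatter) and no change at the digits printed from compound 2 to compound 4 (within the scatter) and a 1.7-fold lower number from compound 1 to compound 4 (0.24 log units; within the scatter) all lie within the scatter. Hydrogen, the two ethers and bromo therefore cannot be told apart at this position. No evidence on the cause of this result is available. Going by these compounds, whether an amine or a carboxylic acid here would move the number beyond the scatter stays open, as does the effect of a longer chain on the oxygen.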